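A few compounds are considered here, and "the series" means these few. Any claim that something is new, unique, unknown or untested is made for them only; others in the source may bear on it.

Three measured compounds share one core and differ only in the chain on the hydrazone carbon. Compound 1 `CC/C(C)=N\Nc1nc(-c2cccc([N+](=O)[O-])c2)cs1` gives 20500 nM in an assay on isolated protein for inhibition of Amine oxidase [flavin-containing] A (Homo sapiens), read by fluorescence, with a stated time of 20 min (on this read-out lower numbers stand for stronger inhibition and higher numbers for weaker inhibition), compound 2 `CCC/C(C)=N\Nc1nc(-c2cccc([N+](=O)[O-])c2)cs1` gives 38000 nM, and compound 3 `C=CCC/C(C)=N\Nc1nc(-c2cccc([N+](=O)[O-])c2)cs1` gives 3990 nM, the lowest of the three numbers. The step of a 1.9-fold higher number from compound 1 to compound 2 (0.27 log units; within the scatter) shows no real change, whereas a 5.1-fold lower number from compound 1 to compound 3 (0.71 log units; beyond the scatter) and a 9.5-fold lower number from compound 2 to compound 3 (0.98 log units; beyond the scatter) both show modest improvement on gaining the double bond. Compound 4 `CCCC/C(C)=N\Nc1nc(-c2cccc([N+](=O)[O-])c2)cs1` differs from compound 3 by ethyl in place of vinyl on a saturated chain carbon, two bonds along the chain from a carbon with a double bond to nitrogen. Compound 4 thus carries a saturated chain like compound 2, which gave 38000 nM. The expected step for compound 4 is accordingly a 6.3-fold higher number from compound 3 to compound 4 (0.80 log units; beyond the scatter), undoing the gain. Compound 4 is estimated at 25000 nM, with a range from 8000 nM to 70000 nM.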

Compound 4, half-maximal inhibitory concentration: 6330 nM
Beside the measured number, compound 4's estimate is 3.9-fold (0.60 log units) above it; measured number below the stated range.
By their numbers in this assay, from the lowest: compounds 3 and 4 (each within the scatter of the next); then compounds 1 and 2 (each within the scatter of the next).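

The double bond is not required at this position: a 1.6-fold higher number from compound 3 to compound 4 (0.20 log units; within the scatter) leaves the butyl chain of compound 4 within the scatter of the but-3-en-1-yl chain of compound 3. Saturated chain length does matter here, since a 6.0-fold lower number from compound 2 to compound 4 (0.78 log units; beyond the scatter) and a 3.2-fold lower number from compound 1 to compound 4 (0.51 log units; beyond the scatter) set the butyl chain apart from both shorter saturated chains. No evidence is available to explain these differences. Going by these compounds, whether a longer chain such as pentyl or hexyl would give lower or higher numbers remains open, as does the effect of an amine at the end of the butyl chain.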